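Aryl swap on a fused tricyclic core: antiproliferative estimate

The source may report more compounds than this note shows. Statements on the series, on what has been measured and on what is new or still open speak of the compounds shown alone.

Measured compounds:
compound 1, `CCC1=C(O)c2c(oc(-c3ccc(O)cc3)cc2=O)C(CC)(CC)C1=O`, 20.6 uM
compound 2, `CCC1=C(O)c2c(oc(-c3ccccc3C(F)(F)F)cc2=O)C(CC)(CC)C1=O`, 43.1 uM

Going by the values given here, compound 1 carries a 4-hydroxyphenyl group on its shared core and, in a functional assay on KBVIN cells (Homo sapiens) for antiproliferative activity, read by sulforhodamine B assay, with a stated time of 3 days (on this read-out lower numbers stand for an effect already at smaller amounts and higher numbers for an effect only at larger amounts of compound), compound 1 gives 20.6 uM, the lowest of the two numbers known. Compound 2 has the nearest value; in this assay compound 2 gives 43.1 uM, which lies beyond the usual scatter above compound 1. Among the compounds with values here, no single-change step between measured compounds is available, so the effect of the aryl group rests on these two values alone.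

Compound 3, `CCC1=C(O)c2c(oc(-c3ccc(C)c(F)c3)cc2=O)C(CC)(CC)C1=O`, differs from compound 1 only in one place: 3-fluoro-4-methylphenyl in place of 4-hydroxyphenyl on an aromatic carbon. Without a matched step to guide the estimate, a modest shift toward higher numbers in this assay is expected from compound 1 to compound 3, of a size about at the edge of the scatter, a 1.5-fold higher number from compound 1 to compound 3 (0.16 log units; within the scatter). Compound 3 is therefore estimated at 30 uM, with a range from 12 uM to 80 uM.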

Compound 3, concentration for half-maximal effect: 2.95 uM
Compound 3: the middle estimate sits 10-fold (1.01 log units) above what was measured, outside the stated range (below it).
By their numbers in this assay, from the lowest: compound 3; then compound 1; then compound 2.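

In this assay, going by these compounds alone, 3-fluoro-4-methylphenyl in place of 4-hydroxyphenyl on the aromatic carbon next to the ring oxygen gives a 7.0-fold lower number from compound 1 to compound 3 (0.84 log units; beyond the scatter), the first single-change step at this position. The number at this position therefore moves with the aryl group it carries, and compound 3 gives 2.95 uM, the lowest of the three numbers. No measurement shown here accounts for the size of this step.

The compounds shown leave open which part of the change carries the step: the loss of the hydroxyl, the arrival of the fluorine, or the arrival of the methyl. As far as these compounds go, how a 4-methylphenyl, a 3-fluorophenyl or a 4-aminophenyl group would read at this position in this assay also remains open.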